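Compound 1 to compound 4: one added methoxy

This account rests on a few compounds, and the source may have more. Where it says the series, first, only, none or still open, it means among the compounds named here.

In a functional assay on A549 cells (Homo sapiens) for cytotoxicity, read by WST assay, with a stated time of 24 h (on this read-out lower numbers stand for stronger inhibition and higher numbers for weaker inhibition), compound 1 `COc1ccc2[nH]cc(/C=C(\C#N)C(=O)c3c[nH]c4ccccc34)c2c1` gives 6600 nM, the lower of the two numbers measured in the series, and compound 3 `N#C/C(=C\c1c[nH]c2ccccc12)C(=O)c1c[nH]c2ccccc12` gives 16100 nM. Compound 2 `COc1ccc2[nH]cc(/C=C(\C#N)C(=O)c3c[nH]c4ccc(OC)cc34)c2c1` reads > 50000 nM, which is a limit of the assay and not a number.

Compound 4 `COc1ccc2c(C(=O)/C(C#N)=C/c3c[nH]c4ccc(OC)cc34)c[nH]c2c1` differs from compound 1 by methoxy in place of hydrogen on an aromatic carbon. The measured step of the same kind is an at least 7.5-fold higher number from compound 1 to compound 2 (0.87 log units; beyond the scatter), beyond the scatter. The reverse exchange gives a 2.4-fold higher number from compound 1 to compound 3 (0.39 log units; beyond the scatter), also beyond the scatter, so removing a methoxy and adding one both raised the number from compound 1. Compound 4 is an isomer of compound 2 and not the same compound, so the full size of the step to compound 2 is not assumed. A moderate rise is expected, and the estimated step is a 3.0-fold higher number from compound 1 to compound 4 (0.48 log units; beyond the scatter) in this assay. For compound 4 the expected value is 20000 nM, with an estimated range of 7000 nM to 50000 nM.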

Compound 4, half-maximal inhibitory concentration: 3700 nM
Compound 4: middle estimate off by 5.4-fold (0.73 log units), on the high side; measured number outside the range, below it.
By their numbers in this assay, from the lowest: compounds 4 and 1 (each within the scatter of the next); then compound 3. At a limit, above all of these: compound 2.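

In this assay, the added methoxy gives a 1.8-fold lower number from compound 1 to compound 4 (0.25 log units; within the scatter), so at this place, meta to a fused ring and para to a fused ring, methoxy in place of hydrogen leaves the number within the scatter. Going by these compounds alone, both earlier steps from compound 1 lay beyond the scatter, and this is the first exchange of hydrogen and methoxy that does not. Compound 2, an isomer of compound 4, stands at a limit of the assay, so the same added group does not read alike at every place: the limit of > 50000 nM in this assay, at which 1 of the 4 values shown sits.

From the compounds shown here alone, whether this place accepts groups other than methoxy stays open; a hydroxyl, an amine or a longer chain such as ethoxy would test it. Going by these compounds, whether compound 4 and compound 1 also read alike in other cell lines or at other times remains unknown.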